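Swapping Furan for Chlorothiophene in a Hydrolase Inhibitor Series

This account rests on a few compounds, and the source may have more. Where it says the series, first, only, none or still open, it means among the compounds named here.

Measured compounds:
compound 1, `Cn1nc2c(=O)n(CC3(O)CCN(Cc4ccc(-c5ccoc5)cc4Cl)CC3)cnc2c1-c1ccc(CN)cc1`, 177 nM
compound 2, `Cn1nc2c(=O)n(CC3(O)CCN(Cc4ccc(-c5ccco5)cc4Cl)CC3)cnc2c1-c1ccc(F)cc1`, 64.5 nM
compound 3, `Cn1nc2c(=O)n(CC3(O)CCN(Cc4ccc(-c5ccco5)cc4Cl)CC3)cnc2c1-c1ccc(C(N)=O)cc1`, 80.8 nM

In an assay on isolated protein for inhibition of ubiquitin carboxyl-terminal hydrolase 7 (Homo sapiens), with stated times of 30 min and 2 h (on this read-out higher numbers stand for weaker inhibition and lower numbers for stronger inhibition), compound 1 gives the highest number of the three, so it is the weakest inhibitor on this read-out. Compound 3 sits nearest to it with a lower number, and compound 2 lies furthest with the lowest number of the set. Going by the values given here, the only step between compounds that differ in a single place is a 1.3-fold higher number from compound 2 to compound 3 (0.10 log units; within the scatter), and it concerns a different part of the molecule from the change considered here.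

Compound 4, `Cn1nc2c(=O)n(CC3(O)CCN(Cc4ccc(-c5ccsc5Cl)cc4Cl)CC3)cnc2c1-c1ccc(CN)cc1`, differs from compound 1 in one place: 2-chlorothiophen-3-yl in place of furan-3-yl on an aromatic carbon. Among the compounds with values here, compounds 2 and 3 differ from compound 1 in more than one place, so no measured step bears on this exchange of five-membered rings. With nothing to point either way, the expectation for compound 4 is a number close to that of compound 1, with no step beyond the scatter: a 1.2-fold lower number from compound 1 to compound 4 (0.07 log units; within the scatter). Compound 4 is therefore estimated at 150 nM, within a range from 55 nM to 400 nM.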

Compound 4, half-maximal inhibitory concentration: 453 nM
Compound 4: middle estimate off by 3.0-fold (0.48 log units), on the low side; the whole stated range lies below it.
By their numbers in this assay, from the lowest: compounds 2 and 3 (each within the scatter of the next); then compound 1; then compound 4.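

The ring on this aromatic carbon, para to a large group, is not freely exchangeable: in this assay the exchange gives a 2.6-fold higher number from compound 1 to compound 4 (0.41 log units; beyond the scatter) and so weakens inhibition beyond the usual scatter. This position therefore responds to the identity of the five-membered ring, even though both rings have the same count of hydrogen-bond donors and acceptors. No measurement shown here accounts for the weaker inhibition.

The exchange replaces the ring oxygen with sulfur and adds a chlorine in a single step, so the contribution of each remains unresolved. Plain thiophen-3-yl on the core of compound 1 would separate the two, while a small amine or a carboxylic acid on the ring would test how much else this position accepts.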